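A few compounds are considered here, and "the series" means these few. Any claim that something is new, unique, unknown or untested is made for them only; others in the source may bear on it.

Measured in a functional assay on NCI-H460 cells (Homo sapiens) for antiproliferative activity, with a stated time of 72 h; on this read-out lower numbers stand for stronger inhibition and higher numbers for weaker inhibition:
- Compound 1 `Nc1ncnn2c([C@@H]3O[C@H](CO)[C@@H](O)[C@H]3O)cc(C#Cc3ccc(F)cc3)c12`: 79400 nM
- Compound 2 `Nc1ncnn2c([C@@H]3O[C@H](CO)[C@@H](O)[C@H]3O)cc(C#Cc3ccccc3)c12`: 38500 nM
- Compound 3 `Cc1ccccc1-c1cc([C@@H]2O[C@H](CO)[C@@H](O)[C@H]2O)n2ncnc(N)c12`: > 100000 nM (a limit of the assay, not a number)

Compound 1 holds the higher of the two true numbers in this assay, and the nearest number lies one step away: a 2.1-fold lower number from compound 1 to compound 2 (0.31 log units; beyond the scatter). The unmeasured compound 4 `Nc1ncnn2c([C@@H]3O[C@H](CO)[C@@H](O)[C@H]3O)cc(-c3ccoc3)c12` differs from it as follows: furan-3-yl in place of 2-(4-fluorophenyl)ethynyl on an aromatic carbon. Thus furan-3-yl stands in place of 2-(4-fluorophenyl)ethynyl on an aromatic carbon.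

Among the compounds with values here, the closest precedent is compound 3, which also carries an aromatic ring on that carbon in place of the ethynyl group: an at least 1.2-fold higher number from compound 1 to compound 3 (0.10 log units; that floor lies within the scatter), and an at least 2.5-fold higher number from compound 2 to compound 3 (0.41 log units; beyond the scatter). Those two steps rest on a limit, so they give only a floor. Within the data shown here, the only step with two true numbers, a 2.1-fold lower number from compound 1 to compound 2 (0.31 log units; beyond the scatter), is modest. Only a modest change is therefore expected in this assay, probably towards a lower number, though the direction is uncertain. The expected step is a 2.0-fold lower number from compound 1 to compound 4 (0.30 log units; within the scatter). Compound 4 is estimated at 40000 nM, with an expected range from 4000 nM to 120000 nM.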

Compound 4, half-maximal inhibitory concentration: 1500 nM
Estimate against measurement, compound 4: 27-fold (1.43 log units) above; the whole stated range lies above it.
By their numbers in this assay, from the lowest: compound 4; then compound 2; then compound 1. At a limit, above all of these: compound 3.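

In this assay, within the data shown here, this position proves far more sensitive than the earlier compounds showed: furan-3-yl gives a 53-fold lower number from compound 1 to compound 4 (1.72 log units; beyond the scatter) and a 26-fold lower number from compound 2 to compound 4 (1.41 log units; beyond the scatter), both large, whereas the only earlier step between two true numbers was modest. Losing the ethynyl link in favour of a ring does not by itself lower the number; going from 2-methylphenyl to furan-3-yl gives an at least 66-fold lower number from compound 3 to compound 4 (1.82 log units; beyond the scatter), a step that is only a floor. Compound 3 stands at a limit of the assay, not a number: the limit of > 100000 nM in this assay, at which 1 of the 4 values shown sits.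

The compounds shown leave open whether the change follows the ring oxygen of furan-3-yl or the smaller five-membered ring, which thiophen-3-yl and unsubstituted phenyl on this carbon would help to separate. Going by these compounds, it also remains open how a pyridine ring or a simple amine would fare at this position.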